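Phenyl for propyl on the chain: cytotoxicity outlook

The source may report more compounds than this note shows. Statements on the series, on what has been measured and on what is new or still open speak of the compounds shown alone.

compound 1 `CCn1nnc(-c2ccc(OCCC(C)CCN3CCN(c4ccncc4)C3=O)cc2)n1` — > 12500 nM
compound 2 `CCCC(CCOc1ccc(-c2ccc(Cl)cc2)cc1)CCN1CCN(c2ccncc2)C1=O` — > 25000 nM
compound 3 `CC(C)(CCCOc1ccc(-c2ccc(Cl)cc2)cc1)CN1CCN(c2ccncc2)C1=O` — 20000 nM

In an ADME assay on cells (Homo sapiens) for cytotoxicity (on this read-out higher numbers stand for lower toxicity in this test and lower numbers for higher toxicity in this test), compound 1 gives > 12500 nM, which is a limit of the assay and not a number. Compound 2 likewise gives only a limit, > 25000 nM. Compound 3 gives 20000 nM. Compound 2 therefore stands at a limit, and one further value of the three is a limit as well. Compound 4 `O=C1N(CCC(CCOc2ccc(-c3ccc(Cl)cc3)cc2)c2ccccc2)CCN1c1ccncc1` differs from compound 2 by phenyl in place of propyl on a saturated chain carbon bound to two saturated chain carbons. For the measured compounds named here, no measured pair among the three shows a change of this kind, so the three values give no direction for it. In this assay the expected step is an at least 1.2-fold lower number from compound 2 to compound 4 (0.09 log units; that floor lies within the scatter), none beyond the usual scatter. Compound 4 is estimated at 20000 nM, with a range from 8000 nM to 40000 nM.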

Compound 4, half-maximal cytotoxic concentration: > 25000 nM
Compound 4 was reported as a limit; the forecaster's own chance of this, stated with the estimate: 50%; middle value at least 1.2-fold (0.09 log units) from the limit.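

Compound 2 and compound 4 both stand only as limits in this assay, not as numbers, and the step between them cannot be read. From the compounds shown here alone, whether phenyl in place of propyl shifts this read-out at all, and in which direction, stays open.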